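Ester Size and Ring Swap in Adenosine Receptor Binding

The source may hold more compounds than are shown below. What is called first, only, known or untested is meant among the compounds shown, and "the series" means these compounds.

Compound 1 `CCCOC(=O)C1=C(C)NC(=O)NC1c1ccoc1` gives 50% in an assay on membranes from CHO cells for displacement of a labelled ligand from adenosine receptor A1 (Homo sapiens), read by scintillation counting, with a stated time of 60 min, tested at 1 uM; on this read-out higher numbers stand for more inhibition at the one concentration tested (going by the name of the read-out) and lower numbers for less inhibition. Compound 2 `CC1=C(C(=O)OC(C)(C)C)C(c2ccoc2)NC(=O)N1` carries tert-butyl in place of propyl on an oxygen next to a carbonyl group and gives 11%, so that a number 39 percentage points lower from compound 1 to compound 2 (beyond the scatter). Compound 3 `CCCOC(=O)C1=C(C)NC(=O)NC1c1ccsc1` gives 44%, and a number 6 percentage points lower from compound 1 to compound 3 (within the scatter). The core of compound 3 differs from the core of compound 1 by thiophen-3-yl in place of furan-3-yl on a saturated ring carbon. Compound 4 `CC1=C(C(=O)OC(C)(C)C)C(c2ccsc2)NC(=O)N1` stands to compound 3 as compound 2 stands to compound 1: it carries tert-butyl in place of propyl on an oxygen next to a carbonyl group, at the very same place, so this is the same change made a second time. For compound 4 a step of about a number 36 percentage points lower from compound 3 to compound 4 (beyond the scatter) is expected because the same change earlier gave a number 39 percentage points lower from compound 1 to compound 2 (beyond the scatter), and this expectation rests on that single earlier step alone. Compound 4 is therefore estimated at 8%, with a range from 0% to 25%.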

Compound 4, a percentage reported as inhibition, at one concentration (the size of the read-out at that concentration, not a potency): 15%
The estimate for compound 4 lay 7 percentage points below the measured number; low and high end bracket the measured number.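

The change from propyl to tert-butyl carries over from one core to the other, giving a number 29 percentage points lower from compound 3 to compound 4 (beyond the scatter), and this step agrees with the earlier one: the same change on two cores in this assay, a number 39 percentage points lower (beyond the scatter) from compound 1 to compound 2 and a number 29 percentage points lower (beyond the scatter) from compound 3 to compound 4, 10 percentage points apart, within the scatter of two such steps

The ring swap also behaves alike on both sides, with thiophen-3-yl in place of furan-3-yl giving a number 4 percentage points higher from compound 2 to compound 4 (within the scatter), which matches the earlier swap: the same change on two cores in this assay, a number 6 percentage points lower (within the scatter) from compound 1 to compound 3 and a number 4 percentage points higher (within the scatter) from compound 2 to compound 4, 10 percentage points apart, within the scatter of two such steps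

For the compounds shown here, this rests on only two cores, so it does not show that the tert-butyl step would hold on any other core, nor does it explain why the step occurs.

The compounds shown leave open what other groups on the same oxygen would do. A longer chain such as pentyl, or a chain ending in an amine, could follow the same trend or break from it.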